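From Chloro to Methyl: Compound 2 to Compound 3

A few compounds are considered here, and "the series" means these few. Any claim that something is new, unique, unknown or untested is made for them only; others in the source may bear on it.

Of the compounds shown here, two have so far been tested in a functional assay on thoracic aorta (Rattus norvegicus, strain Wistar), with a stated time of 15 min; a higher number here means that more compound is needed for the effect, a lower number that less compound is needed. Compound 1 `CC(C)Oc1ccc(Br)cc1C(C)NC(=O)N(C)S(=O)(=O)c1ccccc1` gives 32100 nM in this assay. Compound 2 `COc1ccc(OC)c(CNC(=O)NS(=O)(=O)c2ccc(Cl)cc2)c1` returned no measurable value in this assay; its result of > 300000 nM is a limit of the assay, not a number, as the limit of > 300000 nM in this assay, at which 1 of the 2 values shown sits, records. For the measured compounds named here, compound 2 thus sits at the limit itself, the only one of the two compounds to do so. Compound 3 `COc1ccc(OC)c(CNC(=O)NS(=O)(=O)c2ccc(C)cc2)c1` has not yet been measured. It differs from compound 2 in one place: methyl in place of chloro on an aromatic carbon. Going by the values given here, no measured pair of compounds shows how such an exchange shifts the result, so the expected step that the limit leaves unreadable from compound 2 to compound 3 is none beyond the scatter. Compound 3 is accordingly estimated to give about 400000 nM, within a range from 150000 nM to 1500000 nM, and is expected most often to return only a limit again.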

Compound 3, half-maximal effective concentration: > 300000 nM
Compound 3: no number, only a limit; the forecaster's own chance of this, stated with the estimate: 75%; the middle value does not contradict the limit.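

In this assay, for the compounds shown here, compound 2 and compound 3 each return only a limit of the assay, not a number, so no step between them can be read: the limit of > 300000 nM in this assay, at which 2 of the 3 values shown sit. From the compounds shown here alone, whether methyl in place of chloro on an aromatic carbon shifts the result in this assay at all stays open.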